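This account rests on a few compounds, and the source may have more. Where it says the series, first, only, none or still open, it means among the compounds named here.

Going by the values given here, in an ADME assay on RD cells (Homo sapiens) for cytotoxicity, read by MTT assay, with a stated time of 3 days (a higher number here means that more compound is tolerated, a lower number that less compound is tolerated), compound 2 `Cc1ccc([C@H](CCn2cncn2)Cc2ccccc2)cc1` gives 117 ug/mL, the higher of the two numbers measured so far, while compound 1 `c1ccc(C[C@@H](CCn2cncn2)c2ccccc2)cc1` gives 56 ug/mL. Compound 3 `C[C@H](CCn1cncn1)Cc1ccccc1` differs from compound 2 as follows: methyl in place of 4-methylphenyl on a saturated chain carbon bound to two saturated chain carbons. Among the compounds with values here, the only measured step, a 2.1-fold higher number from compound 1 to compound 2 (0.32 log units; beyond the scatter), is a methyl in place of hydrogen on an aromatic carbon, so it bears only loosely on this much larger exchange and fixes no direction. A moderate rise in this assay is tentatively expected, namely a 1.5-fold higher number from compound 2 to compound 3 (0.19 log units; within the scatter). For compound 3 the estimated value is 180 ug/mL, with an expected range of 70 ug/mL to 450 ug/mL.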

Compound 3, half-maximal cytotoxic concentration: 153 ug/mL
Compound 3: the middle estimate sits 1.2-fold (0.07 log units) above what was measured; the range from low to high includes it.
By their numbers in this assay, from the lowest: compound 1; then compounds 2 and 3 (each within the scatter of the next).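

Methyl in place of 4-methylphenyl on a saturated chain carbon bound to two saturated chain carbons gives a 1.3-fold higher number from compound 2 to compound 3 (0.12 log units; within the scatter), so in this assay this position tolerates losing the aromatic ring without a change beyond the scatter. Methyl in place of phenyl at the same carbon gives a 2.7-fold higher number from compound 1 to compound 3 (0.44 log units; beyond the scatter), a modest step beyond the scatter, so the reading depends on which ring leaves. Nothing available explains this difference. As far as these compounds go, whether a longer chain or an amine at this carbon would fit the same picture remains open.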